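The compounds below may be only part of what the source reports. "The series", "measured", "known", "first", "only" and "open" are said of these compounds alone.

Measured compounds:

Compound 1, `CCSc1ncnc2c1ncn2[C@@H]1O[C@H](CO)[C@@H](O)[C@H]1O`, in an assay on isolated protein for binding affinity to Equilibrative nucleoside transporter 1 (Homo sapiens) (on this read-out lower numbers stand for stronger inhibition and higher numbers for weaker inhibition), compound 1 gives 57500 nM.
Compound 2, `Nc1nc(SCc2cccc(Br)c2)c2ncn([C@@H]3O[C@H](CO)[C@@H](O)[C@H]3O)c2n1`, in this assay compound 2 gives 2880 nM.
Compound 3, `CCCCn1cnc2c(SCc3ccccn3)nc(N)nc21`, in this assay compound 3 gives 52500 nM.

Compound 2 has the lowest number of the three, and both other numbers lie well beyond the scatter above it; it is therefore the strongest inhibitor in this set. No two of these compounds differ in a single place, so the three values show only where each compound stands, not what any single change does.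

Compound 4, `CCC(C)Sc1nc(N)nc2c1ncn2[C@@H]1O[C@H](CO)[C@@H](O)[C@H]1O`, is not yet measured. It is made from compound 2 by one change: sec-butyl in place of 3-bromobenzyl on a sulfur. Among the compounds with values here, the only other compound with a small group on its sulfur, compound 1, gives a much higher number, though compound 1 also lacks the amino group that compounds 2 and 4 share. A step upward, beyond the scatter, is expected from compound 2 to compound 4, about a 6.9-fold higher number from compound 2 to compound 4 (0.84 log units; beyond the scatter), because compound 1 gives 57500 nM with a small group in that place. Compound 4 is estimated at 20000 nM, with a range from 6000 nM to 70000 nM.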

Compound 4, half-maximal inhibitory concentration: 63100 nM
For compound 4 the middle estimate is 3.2-fold (0.50 log units) below the measured one; measured number inside the range.
By their numbers in this assay, from the lowest: compound 2; then compounds 3, 1 and 4 (each within the scatter of the next).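

Within the data shown here, compound 2 and compound 4 share everything except the group on the sulfur, so this pair gives the first direct reading of that position. In this assay, sec-butyl in place of 3-bromobenzyl gives a 22-fold higher number from compound 2 to compound 4 (1.34 log units; beyond the scatter), so with the rest of the molecule unchanged, the choice of group at this position strongly affects inhibition of the transporter. The change swaps a larger group carrying a ring and a bromine for a smaller open chain with neither, and nothing here gives a measured reason for the step.

On these data alone, it remains open whether the ring, the bromine or simply the size of the group accounts for the difference. A plain benzyl group on the sulfur would separate the ring from the bromine, while a cyclohexylmethyl group would show whether the ring must be aromatic.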